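The compounds below may be only part of what the source reports. "The series", "measured", "known", "first", "only" and "open" are said of these compounds alone.

Measured in an ADME assay on microsomes from liver (Canis lupus familiaris) for metabolic stability, read by LC-MS, tested at 1 uM; on this read-out higher numbers stand for fast clearance and lower numbers for slow clearance:
compound 1 `NCCCOc1ccc([C@H]2CC[C@]3(CC2)OOC2(O3)C3CC4CC(C3)CC2C4)cc1` with < 7 mL.min-1.g-1 (a limit of the assay)
compound 2 `NC(=O)C1CCN(Cc2ccc([C@H]3CC[C@]4(CC3)OOC3(O4)C4CC5CC(C4)CC3C5)cc2)CC1` with 10 mL.min-1.g-1 
compound 3 `c1cc([C@H]2CC[C@]3(CC2)OOC2(O3)C3CC4CC(C3)CC2C4)ccc1OC1CCNCC1` with 25 mL.min-1.g-1 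

Compound 1 stands at the limit of < 7 mL.min-1.g-1 in this assay, at which 1 of the 3 values shown sits, and so has no exact number. Compound 4 `N[C@H]1CC[C@@H](Oc2ccc([C@H]3CC[C@]4(CC3)OOC3(O4)C4CC5CC(C4)CC3C5)cc2)CC1` differs from it by 4-aminocyclohexyl in place of 3-aminopropyl on an oxygen on an aromatic ring with 4-aminocyclohexyl in place of 3-aminopropyl on an oxygen on an aromatic ring. The closest measured change is an at least 3.5-fold higher number from compound 1 to compound 3 (0.55 log units; beyond the scatter) where piperidin-4-yl takes that same place. The step of an at least 1.4-fold higher number from compound 1 to compound 2 (0.15 log units; that floor lies within the scatter) bears less, since it replaces the whole 3-aminopropoxy group. A rise of similar size to the closest change is therefore expected in this assay for compound 4. The estimate means an at least 2.5-fold higher number from compound 1 to compound 4 (0.41 log units; beyond the scatter) as an expected step. For compound 4 the expected value is 18 mL.min-1.g-1 with an estimated range from 7 mL.min-1.g-1 to 40 mL.min-1.g-1 in this read-out.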

Compound 4, intrinsic clearance in microsomes: < 7 mL.min-1.g-1
Compound 4 gave a limit, no number; the forecaster's own chance of this, stated with the estimate: 15%; middle value at least 2.5-fold (0.41 log units) away from the limit.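

In this assay, 4-aminocyclohexyl in place of piperidin-4-yl on the oxygen gives an at least 3.5-fold lower number from compound 3 to compound 4 (0.55 log units; beyond the scatter), so a six-membered ring at this position does not by itself bring the higher number of compound 3. Against the other ring-bearing compound, (4-aminocyclohexyl)oxy in place of (4-carbamoylpiperidin-1-yl)methyl gives an at least 1.4-fold lower number from compound 2 to compound 4 (0.15 log units; that floor lies within the scatter). The step between compound 1 and compound 4 cannot be read, because both rest on the same limit: the limit of < 7 mL.min-1.g-1 in this assay, at which 2 of the 4 values shown sit.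

Going by these compounds, the exact numbers behind those two limits stay open. So does how a carboxylic acid or a longer amine chain on that oxygen would read.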